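The source may report more compounds than this note shows. Statements on the series, on what has been measured and on what is new or still open speak of the compounds shown alone.

Compound 1 `O=C(O)c1ccccc1-c1ccc(CCc2ncc(Cc3ccc(Cl)cc3)[nH]2)cc1`: 2290 nM
Compound 2 `CC(C)(C)c1cnc(CCc2ccc(-c3ccccc3C(=O)O)cc2)[nH]1`: 4330 nM

In an in vitro functional assay on cells for agonist activity at Bombesin receptor subtype-3 (Homo sapiens), read by luminescence and calcium flux (on this read-out higher numbers stand for an effect only at larger amounts of compound and lower numbers for an effect already at smaller amounts), compound 2 gives the highest of the two numbers, and its nearest neighbour is compound 1; the step of a 1.9-fold higher number from compound 1 to compound 2 (0.28 log units; within the scatter) lies within the scatter, so the two numbers cannot be told apart. Compound 3 `O=C(O)c1ccccc1-c1ccc(CCc2ncc(CC3CCCCCC3)[nH]2)cc1` differs from compound 2 by cycloheptylmethyl in place of tert-butyl on an aromatic carbon. Within the data shown here, only the step from compound 1 to compound 2 bears on this change, and since it stays within the scatter it gives no direction. For compound 3 a number near that of compound 2 is therefore expected, with the estimated step of a 1.7-fold lower number from compound 2 to compound 3 (0.24 log units; within the scatter) small. The estimate for compound 3 is 2500 nM, between 800 nM and 8000 nM.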

Compound 3, half-maximal effective concentration: 88 nM
For compound 3 the middle estimate is 28-fold (1.45 log units) above the measured one, and the stated range ends above it.
By their numbers in this assay, from the lowest: compound 3; then compounds 1 and 2 (each within the scatter of the next).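

In this assay, this aromatic carbon proves sensitive to the group it carries: cycloheptylmethyl in place of tert-butyl gives a large drop in the number (a 49-fold lower number from compound 2 to compound 3 (1.69 log units; beyond the scatter)). Changing 4-chlorophenyl to cycloheptyl on the saturated chain carbon also matters (a 26-fold lower number from compound 1 to compound 3 (1.42 log units; beyond the scatter)), although the two earlier groups could not be told apart. Nothing available here explains this gain. Still open, on these data alone, is whether cyclohexylmethyl or an open chain such as n-octyl would match cycloheptylmethyl. Also open, as far as these compounds go, is whether a ring carrying an amine would keep the low number.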